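Chloro to Fluoro at the Far End of a Diamine Ligand

The source may hold more compounds than are shown below. What is called first, only, known or untested is meant among the compounds shown, and "the series" means these compounds.

Measured compounds:
compound 1 `Clc1ccc(Nc2ccc(N3CC4CC(C3)N4)cn2)cc1` — 2.49 nM
compound 2 `CN(c1ccccc1)c1cncc(N2CC3CC(C2)N3)c1` — 2.06 nM

In an assay on cell membranes for displacement of a labelled ligand from Neuronal acetylcholine receptor; alpha4/beta2 (Rattus norvegicus) (on this read-out lower numbers stand for stronger inhibition and higher numbers for weaker inhibition), compound 1 gives 2.49 nM. Compound 2 gives 2.06 nM in this assay. Of the two numbers, compound 1 has the higher one, but the gap to compound 2 is within the scatter of repeated measurements, so the two compounds cannot be told apart on these data. Among the compounds with values here, compound 1 and compound 2 differ in several places at once, and no single step between them can be read off.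

Compound 3 `Fc1ccc(Nc2ccc(N3CC4CC(C3)N4)cn2)cc1` has not yet been measured. It differs from compound 1 in one place only: fluoro in place of chloro on an aromatic carbon. Nothing among the two measured compounds tests this particular exchange, so the expectation rests on the change itself. A swap of one halogen for another of the same count of heavy atoms, with no change in donors, acceptors or charge, is expected to move the number by a 1.4-fold higher number from compound 1 to compound 3 (0.15 log units; within the scatter), a step that may not rise above the scatter. Compound 3 is therefore estimated at 3.5 nM in this assay, with a plausible range from 1.2 nM to 10 nM.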

Compound 3, inhibition constant: 2.38 nM
For compound 3 the middle estimate is 1.5-fold (0.17 log units) above the measured one, and the stated range covers the measured number.
By their numbers in this assay, from the lowest: compounds 2, 3 and 1 (each within the scatter of the next).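

In this assay, putting fluoro in place of chloro on an aromatic carbon of the six-membered ring, para to a large group, gives a 1.0-fold lower number from compound 1 to compound 3 (0.02 log units; within the scatter), so the read-out does not separate the two halogens at this position. The earlier compounds shown here could not show this, since compound 1 and compound 2 differ in several places at once and offered no step for any single change; the pair of compound 1 and compound 3 now isolates the exchange of 4-chlorophenyl to 4-fluorophenyl on an otherwise shared structure. No measurement at hand offers an explanation for why these two compounds cannot be told apart.

The compounds shown carry only these two halogens at this position, so they leave open how the number would respond to an amine, a carboxylic acid or a longer chain placed there. They also do not tell whether the same exchange of chloro for fluoro would read alike on compound 2, whose structure differs from that of compound 1 in several places.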